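Amide-aryl variation on the flavonol series: compound 4

The compounds below may be only part of what the source reports. "The series", "measured", "known", "first", "only" and "open" are said of these compounds alone.

Measured so far:
compound 1 `Cc1ccc(C(=O)Nc2cccc(-c3oc4cc(-c5ccc(F)cc5)ccc4c(=O)c3O)c2)cc1` — 4350 nM
compound 2 `Cc1ccccc1C(=O)Nc1cccc(-c2oc3cc(-c4ccc(F)cc4)ccc3c(=O)c2O)c1` — 4910 nM
compound 3 `O=C(Nc1cccc(-c2oc3cc(-c4ccc(F)cc4)ccc3c(=O)c2O)c1)c1ccc(Br)cc1` — 24900 nM

All three share one core and differ only in the aryl group on the carbonyl carbon of the amide. In a functional assay on MDA-MB-231 cells (Homo sapiens) for antiproliferative activity, read by CCK-8 assay, with a stated time of 72 h (a higher number here means a weaker inhibitor, a lower number a stronger inhibitor), compound 1 and compound 2 sit close together, a 1.1-fold higher number from compound 1 to compound 2 (0.05 log units; within the scatter). Compound 3 gives the highest number of the three: a 5.7-fold higher number from compound 1 to compound 3 (0.76 log units; beyond the scatter), and a 5.1-fold higher number from compound 2 to compound 3 (0.71 log units; beyond the scatter). So the two methylphenyl variants are weaker inhibitors by a smaller margin than the bromophenyl variant.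

Compound 4 `O=C(Nc1cccc(-c2oc3cc(-c4ccc(F)cc4)ccc3c(=O)c2O)c1)c1ccc(Cl)nc1` has not yet been measured. Its change from compound 3 is 6-chloropyridin-3-yl in place of 4-bromophenyl on a carbonyl carbon. The ring that enters keeps a halogen and adds one hydrogen-bond acceptor. Among the measured compounds shown here, the only steps that bear on this are those into compound 3, which show that a bromine on that ring raised the number modestly relative to a methyl. Nothing measured here speaks to a ring nitrogen or a chlorine, so the direction is uncertain; a step within the scatter, or a modest lowering back toward compound 1, both seem possible. Compound 4 is therefore expected to give 15000 nM in this assay, with a range from 5000 nM to 45000 nM, which corresponds to an expected step of a 1.7-fold lower number from compound 3 to compound 4 (0.22 log units; within the scatter).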

Compound 4, half-maximal inhibitory concentration: 1760 nM
Beside the measured number, compound 4's estimate is 8.5-fold (0.93 log units) above it; the whole stated range lies above it.
By their numbers in this assay, from the lowest: compound 4; then compounds 1 and 2 (each within the scatter of the next); then compound 3.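

In this assay, among the compounds shown here, the aryl group on the amide carbonyl carbon proves far more sensitive than the methyl-to-bromo comparison suggested: a 14-fold lower number from compound 3 to compound 4 (1.15 log units; beyond the scatter) is the largest step so far, and it comes from replacing 4-bromophenyl with 6-chloropyridin-3-yl, a ring of the same heavy-atom count that still carries a halogen. The new ring does more than recover the level of the methylphenyl compounds, since a 2.8-fold lower number from compound 2 to compound 4 (0.45 log units; beyond the scatter) and a 2.5-fold lower number from compound 1 to compound 4 (0.39 log units; beyond the scatter) both lie beyond the scatter and leave compound 4 with the lowest number of the four. The ring nitrogen and the chlorine enter together in this single change, and no measurement shown accounts for the size of the step.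

The compounds shown leave open how much of the step belongs to the ring nitrogen and how much to the halogen, a question that 4-chlorophenyl and unsubstituted pyridin-3-yl at the same carbonyl carbon would separate. Also open, from the compounds shown here alone, is whether the chlorine on the pyridine ring is needed at all, or whether a methyl, a methoxy or an amine in its place would hold the number at the level of compound 4.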